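A few compounds are considered here, and "the series" means these few. Any claim that something is new, unique, unknown or untested is made for them only; others in the source may bear on it.

Values measured in a toxicity assay on HeLa cells (Homo sapiens) for cytotoxicity, read by MTT assay, with a stated time of 24 h; on this read-out higher numbers stand for weaker inhibition and lower numbers for stronger inhibition:
- Compound 1 `CCOC(=O)N1CCN(C(=S)SCC(O)Cn2c([N+](=O)[O-])cnc2C)CC1`: 1610000 nM
- Compound 2 `Cc1ncc([N+](=O)[O-])n1CC(O)CSC(=S)N1CCN(c2ccccc2)CC1`: > 5000000 nM
- Compound 3 `Cc1ncc([N+](=O)[O-])n1CC(O)CSC(=S)N1CCN(c2ccccn2)CC1`: 2970000 nM

The entry for compound 2, > 5000000 nM, is a limit of the assay and not a number. That leaves compound 3 with one true number for comparison, and that step, a 1.8-fold higher number from compound 1 to compound 3 (0.27 log units; within the scatter), does not separate the two.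

Compound 4 `Cc1ncc([N+](=O)[O-])n1CC(O)CSC(=S)N1CCN(c2cccc(Cl)c2Cl)CC1` differs from compound 3 in one place: 2,3-dichlorophenyl in place of pyridin-2-yl on an amine nitrogen in a ring. This puts 2,3-dichlorophenyl in place of pyridin-2-yl on an amine nitrogen in a ring.

Two measured changes at this nitrogen bear on it. One is an at least 1.6-fold lower number from compound 2 to compound 3 (0.22 log units; that floor lies within the scatter), whose floor is within the scatter. The other is an at least 3.1-fold higher number from compound 1 to compound 2 (0.49 log units; beyond the scatter), a modest change. Compound 2 also has a carbon-only aromatic ring there, so a small rise in this assay is expected, perhaps none beyond the scatter.

The expected change is a 1.2-fold higher number from compound 3 to compound 4 (0.07 log units; within the scatter).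

For compound 4 the estimated value is 3500000 nM, with an expected range of 1300000 nM to 6500000 nM.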

Compound 4, half-maximal inhibitory concentration: 1000000 nM
Compound 4: middle estimate off by 3.5-fold (0.54 log units), on the high side; measured number below the stated range.
By their numbers in this assay, from the lowest: compounds 4, 1 and 3 (each within the scatter of the next, the first and the last beyond it). At a limit, above all of these: compound 2.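

In this assay, for the compounds shown here, the group on this ring nitrogen can shift the result, and the earlier compounds gave only a hint of this among aromatic rings: the step of a 3.0-fold lower number from compound 3 to compound 4 (0.47 log units; beyond the scatter) lies beyond the scatter, so 2,3-dichlorophenyl gives stronger inhibition than pyridin-2-yl. Compound 2 carries a limit and not a number, so the step of an at least 5.0-fold lower number from compound 2 to compound 4 (0.69 log units; beyond the scatter) gives only a floor, but that floor also lies beyond the scatter and shows that a plain phenyl ring does not behave like 2,3-dichlorophenyl here: the limit of > 5000000 nM in this assay, at which 1 of the 4 values shown sits. The step of a 1.6-fold lower number from compound 1 to compound 4 (0.21 log units; within the scatter) lies within the scatter, so 2,3-dichlorophenyl and ethoxycarbonyl are not separated.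

On these data alone, whether both chlorines are needed stays open. So does what a methoxy group, a nitrile or a carboxylic acid on the phenyl ring would give.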